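Pyridin-2-yl in place of a hydroxylated fluorophenyl

This account rests on a few compounds, and the source may have more. Where it says the series, first, only, none or still open, it means among the compounds named here.

Measured so far:
compound 1, `Cc1ccc(Nc2nc3nonc3nc2Nc2ccccc2F)cc1`, 2100 nM
compound 2, `Oc1ccc(F)c(Nc2nc3nonc3nc2Nc2ccccc2F)c1`, 30000 nM

Compound 1 carries a 4-methylphenyl on one of the two nitrogens of the shared core, compound 2 a 2-fluoro-5-hydroxyphenyl at the same place. In an assay on mitochondria from L6 cells (Rattus norvegicus) for activation, with a stated time of 90 min (a higher number here means that more compound is needed for the effect, a lower number that less compound is needed), compound 1 gives 2100 nM, while compound 2 gives 30000 nM. Going by the values given here, of the two numbers, compound 2 stands at the higher one, and the only step between measured compounds, a 14-fold higher number from compound 1 to compound 2 (1.15 log units; beyond the scatter), is large and beyond the scatter.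

Compound 3, `Fc1ccccc1Nc1nc2nonc2nc1Nc1ccccn1`, is not yet measured. It differs from compound 2 in one place: pyridin-2-yl in place of 2-fluoro-5-hydroxyphenyl on a nitrogen on an aromatic ring. Among the compounds with values here, no measured step involves a pyridin-2-yl, so the step from compound 1 to compound 2 is the only guide, and it shows only that this position is sensitive to what is attached. Because compound 2 already stands at the highest number with 30000 nM, the expectation for compound 3 is a lower number, though of uncertain size. Compound 3 is therefore estimated at 6000 nM, with a range from 1500 nM to 25000 nM. This estimate corresponds to an expected step of a 5.0-fold lower number from compound 2 to compound 3 (0.70 log units; beyond the scatter).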

Compound 3, half-maximal effective concentration: 9000 nM
Compound 3: middle estimate off by 1.5-fold (0.18 log units), on the low side, and the stated range covers the measured number.
By their numbers in this assay, from the lowest: compound 1; then compound 3; then compound 2.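

In this assay the pyridin-2-yl brings a 3.3-fold lower number from compound 2 to compound 3 (0.52 log units; beyond the scatter) and still leaves a 4.3-fold higher number from compound 1 to compound 3 (0.63 log units; beyond the scatter) on the same nitrogen, so compound 3 lies between the two earlier compounds. Where compound 1 and compound 2 carry rings of carbon only, compound 3 shows that a six-membered aromatic ring with a hetero atom can stand on this nitrogen and give a number inside the span of the two earlier groups, while the 4-methylphenyl keeps the lowest number of the three. The change from compound 2 to compound 3 removes the fluorine and the oxygen and puts a nitrogen into the ring all at once, so the step cannot be assigned to any one of these features.

On these data alone, whether the ring nitrogen or the absent methyl separates compound 3 from compound 1 stays open, and a plain phenyl, a pyridin-3-yl, a pyridin-4-yl or a pyridine ring carrying a methyl on this nitrogen would speak to that question. No accompanying measurement explains any of these steps.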